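The source may report more compounds than this note shows. Statements on the series, on what has been measured and on what is new or still open speak of the compounds shown alone.

Measured compounds:
- Compound 1 `COc1ccc(/C=C/C(=O)c2ccc(OC)c3c2OC(C)(C)C=C3)c(F)c1`; in a functional assay on SK-OV-3 cells (Homo sapiens) for antiproliferative activity, read by MTT assay, with a stated time of 24 h (a higher number here means a weaker inhibitor, a lower number a stronger inhibitor), compound 1 gives 4880 nM.
- Compound 2 `COc1ccc(C(=O)/C=C/c2ccc(Br)cc2)c2c1C=CC(C)(C)O2`; in this assay compound 2 reaches only the limit > 10000 nM.
- Compound 3 `COc1ccc(C(=O)/C=C/c2cccc(Cl)c2)c2c1C=CC(C)(C)O2`; in this assay compound 3 reaches only the limit > 10000 nM.

Compound 3 therefore stands at the limit, not at a number, together with compound 2 (the limit of > 10000 nM in this assay, at which 2 of the 3 values shown sit). Compound 4 `COc1ccccc1/C=C/C(=O)c1ccc(OC)c2c1OC(C)(C)C=C2` differs from compound 3 by 2-methoxyphenyl in place of 3-chlorophenyl on a double-bonded chain carbon bound to a double-bonded chain carbon. Among the compounds with values here, the steps that bear on this are an at least 2.0-fold higher number from compound 1 to compound 2 (0.31 log units; beyond the scatter) and an at least 2.0-fold higher number from compound 1 to compound 3 (0.31 log units; beyond the scatter), both at least modest; a step that the two limits leave unreadable from compound 2 to compound 3. Compound 4 carries a methoxy group, as does compound 1, so a move back toward the number of compound 1 is expected, but only as a guess, since compound 3 offers no number to start from. The expected step is an at least 1.2-fold lower number from compound 3 to compound 4 (0.09 log units; that floor lies within the scatter). Compound 4 is estimated at 8000 nM in this assay, between 3000 nM and 20000 nM.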

Compound 4, half-maximal inhibitory concentration: > 10000 nM
Compound 4: a limit, no number; the forecaster's own chance of this, stated with the estimate: 45%; middle value at least 1.2-fold (0.09 log units) away from the limit.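

A methoxy group alone does not restore a measurable number at this position: 2-methoxyphenyl in place of 2-fluoro-4-methoxyphenyl gives an at least 2.0-fold higher number from compound 1 to compound 4 (0.31 log units; beyond the scatter). Compound 4 gives only a limit in this assay, not a number: the limit of > 10000 nM in this assay, at which 3 of the 4 values shown sit. The steps among compound 2, compound 3 and compound 4 cannot be read, and 2-fluoro-4-methoxyphenyl remains the only group shown here with a number.

Going by these compounds, it remains open which part of 2-fluoro-4-methoxyphenyl goes with that number. Also open, on these data alone, is how an amine or a carboxylic acid on this phenyl ring would read.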